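The source may report more compounds than this note shows. Statements on the series, on what has been measured and on what is new or still open speak of the compounds shown alone.

Measured so far in a functional assay on HepG2 cells (Homo sapiens) for antiproliferative activity, read by MTT assay, with a stated time of 48 h; on this read-out lower numbers stand for an effect already at smaller amounts and higher numbers for an effect only at larger amounts of compound:

compound 1, `CC1=NN(C(=O)CCl)C(c2cc(Cl)ccc2O)C1`, 20300 nM
compound 2, `CC1=NN(C(=O)CCl)C(c2cc(F)ccc2O)C1`, 4210 nM
compound 3, `CC1=NN(S(=O)(=O)c2ccc(F)cc2)C(c2cc(Br)ccc2O)C1`, 50100 nM

Compound 4, `CC1=NN(S(=O)(=O)c2ccc(Cl)cc2)C(c2cc(Br)ccc2O)C1`, has not yet been measured in this assay. Compound 2 and compound 3 are built on different cores; the difference between the two cores is not broken down here.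

Among the measured compounds, one change has already been tried: chloro in place of fluoro on an aromatic carbon. That step gave a 4.8-fold higher number from compound 2 to compound 1 (0.68 log units; beyond the scatter). The change from compound 3 to compound 4 is the same kind of change, (chloro in place of fluoro on an aromatic carbon), but its surroundings differ: in the earlier pair the place is meta to a large group and para to a hydroxy group, while in compound 4 it is para to a large group, on a different core.

Going by the values given here, since only this one earlier step is available, and on another core, the expectation rests on it loosely. Compound 4 is expected to show a 1.6-fold higher number from compound 3 to compound 4 (0.20 log units; within the scatter) in this assay, a smaller move than the earlier one, with compound 3 at 50100 nM as the starting point. Compound 4 is therefore estimated at 80000 nM, between 25000 nM and 200000 nM.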

Compound 4, half-maximal effective concentration: > 60000 nM
Compound 4 gave a limit, no number; the forecaster's own chance of this, stated with the estimate: 30%; the middle value lies beyond the limit too.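

In this assay, compound 4 gives > 60000 nM, which is a limit of the assay and not a number. The step from 4-fluorophenyl to 4-chlorophenyl can therefore be read only as a floor, an at least 1.1-fold higher number from compound 3 to compound 4 (0.07 log units; that floor lies within the scatter), so this result does not go against the earlier step, but it does not give the size of the change on this core either. The change has now been tried on two cores, but these results do not show whether its effect carries from one core to the other at the same size: the same change on two cores in this assay, a 4.8-fold higher number (0.68 log units; beyond the scatter) from compound 2 to compound 1 and an at least 1.1-fold higher number (0.07 log units; that floor lies within the scatter) from compound 3 to compound 4; the limit leaves it open whether they differ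

As far as these compounds go, only these two pairs carry the change, so it remains open whether a third core would follow either of them. The compounds shown also leave open whether a methoxy group, an amine or a carboxylic acid in place of the chloro of compound 4 would give a number that can be read in this assay.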